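Moving the chlorine in compound 1

The compounds below may be only part of what the source reports. "The series", "measured", "known", "first", "only" and "open" are said of these compounds alone.

Compound 1 `C#CCSc1nc(Sc2nnnn2CCN(C)C)c(C#N)c(-c2ccc(Cl)cc2)n1`: 7170 nM
Compound 2 `C#CCSc1nc(Sc2nncs2)c(C#N)c(-c2cc(OC)c(OC)c(OC)c2)n1`: 10300 nM
Compound 3 `C#CCSc1nc(Sc2nccs2)c(C#N)c(-c2ccc(Cl)cc2)n1`: 3620 nM

In a functional assay on PC-3 cells (Homo sapiens) for antiproliferative activity, read by MTT assay, with a stated time of 72 h (on this read-out higher numbers stand for weaker inhibition and lower numbers for stronger inhibition), compound 1 gives 7170 nM, a number within the scatter of those of both other compounds. Compound 4 `C#CCSc1nc(Sc2nnnn2CCN(C)C)c(C#N)c(-c2cccc(Cl)c2)n1` has the same atoms as compound 1, joined differently: 3-chlorophenyl in place of 4-chlorophenyl on an aromatic carbon. Within the data shown here, the one measured step, a 2.0-fold lower number from compound 1 to compound 3 (0.30 log units; within the scatter), replaces a group on a sulfur, leaves the 4-chlorophenyl untouched, and stays within the scatter. Among the measured compounds shown here, no measured pair isolates the change from 4-chlorophenyl to 3-chlorophenyl, so no step beyond the scatter is expected in this assay, in either direction. Compound 4 is expected at 7000 nM, with an estimated range of 3000 nM to 16000 nM. This estimate amounts to an expected 1.0-fold lower number from compound 1 to compound 4 (0.01 log units; within the scatter).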

Compound 4, half-maximal inhibitory concentration: 3540 nM
Estimate against measurement, compound 4: 2.0-fold (0.30 log units) above; low and high end bracket the measured number.
By their numbers in this assay, from the lowest: compounds 4, 3, 1 and 2 (each within the scatter of the next, the first and the last beyond it).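

In this assay, moving the chlorine from 4-chlorophenyl to 3-chlorophenyl gives a 2.0-fold lower number from compound 1 to compound 4 (0.31 log units; beyond the scatter) with no change in the atoms, so at this position the place of the chlorine alone shifts the number modestly beyond the scatter. Among these compounds, the one earlier step left the 4-chlorophenyl untouched and could not show this. The compounds shown leave open whether an amine or a carboxylic acid in place of the chlorine would shift the number, and whether the same move on compound 3 would give a similar step. No measurement shown bears on the cause of this step.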